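From 4-iodophenyl to 3-ethylphenyl on the shared core

This account rests on a few compounds, and the source may have more. Where it says the series, first, only, none or still open, it means among the compounds named here.

In an ADME assay on BJ cells (Homo sapiens) for cytotoxicity, with a stated time of 72 h (a lower number here means that less compound is needed, a higher number that more compound is needed for the effect), compound 3 (`Cc1nn(-c2ccccc2)c2nc(-c3ccc(I)cc3)c(C#N)c(-c3ccccc3O)c12`) gives 19000 nM. Compound 1 (`CCCc1ccc(-c2nc3c(c(C)nn3-c3ccccc3)c(-c3ccccc3O)c2C#N)cc1`) gives 22500 nM, a value within the scatter of the one before it. Compound 2 (`Cc1nn(-c2ccccc2)c2nc(-c3ccc(Cl)cc3)c(C#N)c(-c3ccccc3O)c12`) reads > 20000 nM, which is a limit of the assay and not a number.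

Compound 4 (`CCc1cccc(-c2nc3c(c(C)nn3-c3ccccc3)c(-c3ccccc3O)c2C#N)c1`) has 3-ethylphenyl in place of 4-iodophenyl on an aromatic carbon, next to the ring nitrogen and ortho to a cyano group: 3-ethylphenyl in place of 4-iodophenyl on an aromatic carbon. Three measured steps change a group on this same phenyl ring. Iodo in place of propyl gave a 1.2-fold lower number from compound 1 to compound 3 (0.07 log units; within the scatter). Iodo in place of chloro gave an at least 1.0-fold lower number from compound 2 to compound 3 (0.02 log units; that floor lies within the scatter). Chloro in place of propyl gave a step that the limit leaves unreadable from compound 1 to compound 2. For the measured compounds named here, no measured compound carries a 3-ethylphenyl group, so these steps are only an indirect guide.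

Going by the values given here, with the one readable step inside the scatter, no change beyond the scatter is expected in this assay. The estimate corresponds to a 1.1-fold higher number from compound 3 to compound 4 (0.02 log units; within the scatter). For compound 4 the estimated value is 20000 nM, with an expected range from 10000 nM to 40000 nM.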

Compound 4, half-maximal effective concentration: > 20000 nM
Compound 4 ended at the assay's limit; the forecaster's own chance of this, stated with the estimate: 35%; the middle value sits exactly at the limit.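

In this assay, 3-ethylphenyl in place of 4-iodophenyl gave an at least 1.0-fold higher number from compound 3 to compound 4 (0.02 log units; that floor lies within the scatter). The earlier compounds shown here carried only 4-chlorophenyl, 4-iodophenyl or 4-propylphenyl at this position, on the carbon next to the ring nitrogen and ortho to a cyano group, and compound 4 adds a 3-ethylphenyl group that gives no separation from compound 3 beyond the scatter. The steps from compound 1 and from compound 2 to compound 4 cannot be read because the values involved include a limit of the assay and not a number: the limit of > 20000 nM in this assay, at which 2 of the 4 values shown sit.

From the compounds shown here alone, how far compound 2 and compound 4 lie past that limit stays open. So does whether a group of another kind on this phenyl ring, such as an amine or a carboxylic acid, would move the number beyond the scatter.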